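From piperidin-4-yl to methyl on compound 2

A few compounds are considered here, and "the series" means these few. Any claim that something is new, unique, unknown or untested is made for them only; others in the source may bear on it.

In a functional assay on BT-474 cells (Homo sapiens) for antiproliferative activity, read by MTT assay, with a stated time of 72 h (a lower number here means a stronger inhibitor, a higher number a weaker inhibitor), compound 1 `CC(Oc1nc(N)nc2ccc(-c3cnn(C4CCNCC4)c3)cc12)c1c(Cl)ccc(F)c1Cl` gives 3000 nM. Compound 2 `CC(Oc1ncnc2ccc(-c3cnn(C4CCNCC4)c3)cc12)c1c(Cl)ccc(F)c1Cl`, with hydrogen in place of amino on an aromatic carbon, gives 4140 nM. Among the compounds with values here, the two values lie within the scatter of each other, and they are the only numbers available here. Compound 3 `COc1cccc(CNc2ncnc3ncc(-c4cnn(C)c4)cc23)c1`, which has a different core but carries the 1-methyl-1H-pyrazol-4-yl group, is reported only as a limit, > 100000 nM.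

The step followed here leads to compound 4 `CC(Oc1ncnc2ccc(-c3cnn(C)c3)cc12)c1c(Cl)ccc(F)c1Cl`, with methyl in place of piperidin-4-yl on an aromatic nitrogen. Within the data shown here, no measured step makes this change. The only one available is a 1.4-fold higher number from compound 1 to compound 2 (0.14 log units; within the scatter), which lies elsewhere on the molecule and within the scatter, so it sets no size for the present step. The one pointer is indirect: compound 3 shares the entering group and sits at > 100000 nM, a limit, but its core differs, so it is weak evidence that this assay will give a higher number for compound 4. A moderate shift towards weaker inhibition is therefore expected, estimated as a 2.9-fold higher number from compound 2 to compound 4 (0.46 log units; beyond the scatter). The expected value for compound 4 is 12000 nM, with an estimated range of 3000 nM to 50000 nM.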

Compound 4, half-maximal inhibitory concentration: 45600 nM
Estimate against measurement, compound 4: 3.8-fold (0.58 log units) below; low and high end bracket the measured number.
By their numbers in this assay, from the lowest: compounds 1 and 2 (each within the scatter of the next); then compound 4. At a limit, above all of these: compound 3.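

In this assay, the change from 1-(piperidin-4-yl)-1H-pyrazol-4-yl to 1-methyl-1H-pyrazol-4-yl now has a measured size at this aromatic nitrogen, and it is large: an 11-fold higher number from compound 2 to compound 4 (1.04 log units; beyond the scatter). The only earlier step, a 1.4-fold higher number from compound 1 to compound 2 (0.14 log units; within the scatter), lay elsewhere on the molecule and within the scatter, so this is the first change among the compounds shown that moves the number beyond it. Within the data shown here, compound 3, with its different core, remains the only compound reported as a limit rather than a number: the limit of > 100000 nM in this assay, at which 1 of the 4 values shown sits.

The compounds shown leave open which part of the piperidin-4-yl group carries the difference: a tetrahydropyran-4-yl ring would keep a six-membered ring without the amine, and a 2-aminoethyl chain would keep an amine without the ring. Also open, as far as these compounds go, is whether the same exchange, with the amino group of compound 1 in place on the core, would give a step of similar size.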